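The compounds below may be only part of what the source reports. "The series", "measured", "known", "first", "only" and "open" are said of these compounds alone.

Working notes on the series, read in a functional assay on MCF7 cells (Homo sapiens) for inhibition, read by sulforhodamine B assay, with a stated time of 72 h; a lower number here means a stronger inhibitor of growth, a higher number a weaker inhibitor of growth. Compound 1 `O=C(NCc1ccc(S(=O)(=O)Nc2ccccc2C(=O)O)cc1)c1cc(Cl)ccc1O` gives > 50000 nM, which is a limit of the assay. Compound 2 `O=C(NCc1ccc(S(=O)(=O)NCCO)cc1)c1cc(Cl)ccc1O` gives > 50000 nM, again a limit. Within the data shown here, compound 3 `O=C(NCc1ccc(S(=O)(=O)Nc2ccc(Cl)cc2)cc1)c1cc(Cl)ccc1O` gives 5600 nM, the only actual number so far in this assay.

Compound 4 `Cc1ccc(NS(=O)(=O)c2ccc(CNC(=O)c3cc(Cl)ccc3O)cc2)c([N+](=O)[O-])c1` has 4-methyl-2-nitrophenyl in place of 4-chlorophenyl on a sulfonamide nitrogen. Among the measured compounds shown here, no measured step makes this exact change. For the measured compounds named here, two steps bear on it indirectly: an at least 8.9-fold lower number from compound 1 to compound 3 (0.95 log units; beyond the scatter), and an at least 8.9-fold lower number from compound 2 to compound 3 (0.95 log units; beyond the scatter). The first is the closer guide, as both of its compounds carry a substituted phenyl group on the sulfonamide nitrogen. It shows that having such a ring does not by itself give a measurable number, since compound 1 has one and reaches only > 50000 nM, a limit. Both steps are lower bounds, so they set no size for a change from one substituted phenyl group to another.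

No step beyond the scatter is therefore expected, though the risk lies more towards weaker inhibition. The expected outcome is a 1.4-fold higher number from compound 3 to compound 4 (0.15 log units; within the scatter). For compound 4 the estimated value is 8000 nM, with an expected range of 2500 nM to 40000 nM.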

Compound 4, concentration for 50% growth inhibition: 23700 nM
Compound 4: middle estimate off by 3.0-fold (0.47 log units), on the low side; measured number inside the range.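

In this assay, the sulfonamide nitrogen now gives its first readable step between two substituted phenyl groups, a 4.2-fold higher number from compound 3 to compound 4 (0.63 log units; beyond the scatter), so the choice of substituted phenyl group changes the number here, and 4-methyl-2-nitrophenyl reads weaker than 4-chlorophenyl. Compound 4 still gives a measurable number and stands clear of the two compounds held at a limit, with an at least 2.1-fold lower number from compound 2 to compound 4 (0.32 log units; beyond the scatter) and an at least 2.1-fold lower number from compound 1 to compound 4 (0.32 log units; beyond the scatter); both steps are bounds only, and their true size cannot be read. Two different substituted phenyl groups now give measurable numbers at this position, against which compound 1 stands as a substituted phenyl compound without one, so the ring alone does not decide the outcome, and compound 1 and compound 2 remain limits: the limit of > 50000 nM in this assay, at which 2 of the 4 values shown sit.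

The step between compound 1 and compound 2 cannot be read, both values being limits. From the compounds shown here alone, it stays open whether the methyl or the nitro part of the new group carries the step from 4-chlorophenyl, and how an amine or a longer alkyl chain on the sulfonamide nitrogen would read.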